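Methoxy in place of ethyl: working notes on the series

This account rests on a few compounds, and the source may have more. Where it says the series, first, only, none or still open, it means among the compounds named here.

In a functional assay on the whole organism for inhibition, with Rattus norvegicus as the target (on this read-out higher numbers stand for an effect only at larger amounts of compound and lower numbers for an effect already at smaller amounts), compound 1 `CC(C)c1ccc(OC(C)(Cc2ccc(Cl)cc2)C(=O)O)cc1` gives 1 mg/kg; 1 mg/kg; 1 mg/kg (3 entries) across its entries, while compound 2 `CCc1ccccc1CC(C)(Oc1ccc(C(C)C)cc1)C(=O)O` gives 5 mg/kg as the only number shown, with one further entry that carries no single number. Among the compounds with values here, the series offers no measured step between compounds that differ in one place. Compound 3 `COc1ccccc1CC(C)(Oc1ccc(C(C)C)cc1)C(=O)O` departs from compound 2 by a single change, methoxy in place of ethyl on an aromatic carbon, ortho to a large group methoxy in place of ethyl on an aromatic carbon with the rest of the structure kept. Within the data shown here, with no measured step to draw on, the expectation rests on compound 2 at 5 mg/kg and on this one exchange in this assay alone. The expected change a 1.3-fold lower number from compound 2 to compound 3 (0.10 log units; within the scatter) is small, with no firm direction and nothing beyond the usual scatter. For compound 3 the estimate is 4 mg/kg with 1.5 mg/kg to 12 mg/kg as its expected range.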

Compound 3, dose for half-maximal effect: > 10 mg/kg
Compound 3: no number, only a limit; the forecaster's own chance of this, stated with the estimate: 10%; middle value at least 2.5-fold (0.39 log units) from the limit.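

Within the data shown here, this is the first measured step, and it falls on an aromatic carbon ortho to a large group, where 2-ethylphenyl becomes 2-methoxyphenyl with the rest of the structure kept. In this assay, compound 3 gives only a limit, > 10 mg/kg, and not a number. The exchange, which keeps the count of heavy atoms and adds one hydrogen-bond acceptor, reads as an at least 2.0-fold higher number from compound 2 to compound 3 (0.30 log units; that floor lies within the scatter), so the direction points upward while the size is only a floor that does not clear the scatter: the limit of > 10 mg/kg in this assay, at which 1 of the 3 values shown sits.

As far as these compounds go, how far compound 3 lies past its limit stays open, so the true size of this step cannot be told. Also open, from the compounds shown here alone, is how a chlorine, a hydroxyl or a longer chain such as propyl would read at this same place.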